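The source may hold more compounds than are shown below. What is called first, only, known or untested is meant among the compounds shown, and "the series" means these compounds.

Compound 1 `COc1cc(-c2nn(-c3cccc(NC(=O)c4cccc(C(F)(F)F)c4)c3)cc2-c2ccncc2)ccc1Cl` shows the highest number of the three compounds measured in a functional assay on OVCAR-5 cells (Homo sapiens) for inhibition, read by sulforhodamine B assay, with a stated time of 48 h; on this read-out lower numbers stand for stronger inhibition of growth and higher numbers for weaker inhibition of growth: in this assay compound 1 gives 4010 nM. Compound 2 `COc1cc(-c2nn(-c3cccc(NC(=O)Nc4cccc(C(F)(F)F)c4)c3)cc2-c2ccncc2)ccc1Cl` gives 1270 nM, and compound 3 `O=C(Nc1cccc(-n2cc(-c3ccncc3)c(-c3ccc(Cl)c(O)c3)n2)c1)Nc1cc(C(F)(F)F)cc(C(F)(F)F)c1` gives 875 nM, so compound 1 sits at the top of the measured range, with both other numbers lying beyond the scatter from it. Compound 4 `COc1cc(-c2nn(-c3cccc(NC(=O)Nc4ccc(Cl)c(C(F)(F)F)c4)c3)cc2-c2ccncc2)ccc1Cl` has not yet been measured. It differs from compound 1 in one place: (4-chloro-3-(trifluoromethyl)phenyl)amino in place of 3-(trifluoromethyl)phenyl on a carbonyl carbon. The measured step that bears on this is a 3.2-fold lower number from compound 1 to compound 2 (0.50 log units; beyond the scatter), in which an amino-linked ring likewise took the place of the directly attached ring on the carbonyl carbon. Compound 4 carries that same kind of change, with a chlorine added to the entering ring. Among the measured compounds shown here, compound 3 comes from a different core, so its number offers no direct step here. Compound 4 is therefore expected to move by about a 4.0-fold lower number from compound 1 to compound 4 (0.60 log units; beyond the scatter), in the same direction as compound 2. The estimate for compound 4 in this assay is 1000 nM, with a range from 400 nM to 2500 nM.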

Compound 4, concentration for 50% growth inhibition: 3090 nM
Beside the measured number, compound 4's estimate is 3.1-fold (0.49 log units) below it; the measured number lies above the stated range.
By their numbers in this assay, from the lowest: compounds 3 and 2 (each within the scatter of the next); then compounds 4 and 1 (each within the scatter of the next).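

Adding a single chlorine to the ring on the amino-linked side is not neutral in this assay: chloro in place of hydrogen on an aromatic carbon gives a 2.4-fold higher number from compound 2 to compound 4 (0.39 log units; beyond the scatter). The full replacement of 3-(trifluoromethyl)phenyl by (4-chloro-3-(trifluoromethyl)phenyl)amino gives a 1.3-fold lower number from compound 1 to compound 4 (0.11 log units; within the scatter), so the amino link does not give a separation from compound 1 when this chlorine is also present, unlike the earlier step of a 3.2-fold lower number from compound 1 to compound 2 (0.50 log units; beyond the scatter). No measured evidence here explains this result.

The compounds shown leave open whether a fluorine, a methyl group or a methoxy group on that same ring carbon would behave like chlorine. They also leave open how chlorine would act on the directly attached ring of compound 1, with no amino link.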